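Fluoro on the phenyl ring of two triazole sulfur oxides

The source may hold more compounds than are shown below. What is called first, only, known or untested is meant among the compounds shown, and "the series" means these compounds.

Measured so far, in a functional assay on the whole organism for antagonist activity, with Mus musculus as the target; a lower number here means that less compound is needed, a higher number that more compound is needed for the effect:
- compound 1 `CC[S+]([O-])c1nnc(-c2ccccc2)n1C`, a limit: > 200 mg/kg
- compound 2 `CC[S+]([O-])c1nnc(-c2ccccc2F)n1C`, a limit: > 200 mg/kg
- compound 3 `Cn1nc(-c2ccccc2)nc1S(C)(=O)=O`, a limit: > 200 mg/kg

All three values are limits of this assay, not numbers. The change from compound 1 to compound 2 is fluoro in place of hydrogen on an aromatic carbon; its step is a step that the two limits leave unreadable from compound 1 to compound 2, unreadable since both ends sit at the limit, as the limit of > 200 mg/kg in this assay, at which 3 of the 3 values shown sit, states. How the core of compound 3 differs from that of compound 1 is not broken down here.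

Compound 4 `Cn1nc(-c2cccc(F)c2)nc1S(C)(=O)=O` is not yet measured. Its change from compound 3 is fluoro in place of hydrogen on an aromatic carbon, the same kind of change as from compound 1 to compound 2, though placed meta to a large group rather than ortho to a large group. With three of three values at the limit, the step from compound 3 to compound 4 in this assay is expected to be a step that the limit leaves unreadable from compound 3 to compound 4, resting on compound 3 at > 200 mg/kg. Compound 4 is therefore expected near 300 mg/kg, between 150 mg/kg and 1000 mg/kg, most likely again reported only as a limit.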

Compound 4, dose for half-maximal effect: > 100 mg/kg
Compound 4: a limit, no number; the forecaster's own chance of this, stated with the estimate: 85%; the middle value does not contradict the limit.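

Going by these compounds alone, compound 3 and compound 4 both carry limits, not numbers, and no step between them can be read. What fluoro in place of hydrogen on an aromatic carbon does in this assay stays open: none of the compounds shown gives a number.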